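The compounds below may be only part of what the source reports. "The series", "measured", "known", "first", "only" and "open" are said of these compounds alone.

Of the compounds shown here, three have so far been measured in an ADME assay on microsomes from liver (Homo sapiens) for metabolic stability, read by LC-MS, with a stated time of 30 min, tested at 1 uM; a higher number here means that more of the compound is left, a lower number that less of the compound is left. Compound 1 `O=C(NCc1ccc(S(=O)(=O)c2cc(F)cc(F)c2)cc1)c1cc2ccncc2o1` gives 77% in this assay. Compound 2 `O=C(NCc1ccc(S(=O)(=O)N2CCCCC2)cc1)c1cc2ccncc2[nH]1` gives 50% in this assay. Compound 3 `O=C(NCc1ccc(S(=O)(=O)c2ccccc2)cc1)c1cc2ccncc2s1` gives 48% in this assay. Compound 3 therefore holds the lowest of the three numbers. Its nearest neighbour is compound 2, whose number lies within the scatter of that of compound 3, so no order can be read between those two. Compound 1 stands furthest off, beyond the scatter. Going by the values given here, no pair among the three measured compounds differs in only one place, so no measured step is available.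

Compound 4 `O=C(NCc1ccc(S(=O)(=O)c2ccccc2)cc1)c1cn2ccnc2cn1` has not yet been measured in this assay. It differs from compound 3 in one place: a group of 9 heavy atoms (6 carbon, 3 nitrogen; one five-membered aromatic ring with 2 hetero atoms, one six-membered aromatic ring with 2 hetero atoms) in place of a group of 9 heavy atoms (7 carbon, 1 nitrogen, 1 sulfur; one five-membered aromatic ring with 1 hetero atom, one six-membered aromatic ring with 1 hetero atom), on a carbonyl carbon. The measured compounds give no guide for a change of this kind. Compound 4 is expected to give 55% in this assay, with a range from 30% to 80%. The expected step of a number 7 percentage points higher from compound 3 to compound 4 (within the scatter) is thus one that stays within the scatter.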

Compound 4, percent of the compound remaining: 87%
Compound 4: the middle estimate sits 32 percentage points below what was measured, and the stated range ends below it.
By their numbers in this assay, from the lowest: compounds 3 and 2 (each within the scatter of the next); then compounds 1 and 4 (each within the scatter of the next).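

Going by these compounds alone, the first measured step in this set that differs in one place shows that the group on a carbonyl carbon, with the amide-type nitrogen as its other neighbour, matters in this assay: the exchange gives a number 39 percentage points higher from compound 3 to compound 4 (beyond the scatter) while the rest of the structure stays the same. The two groups have the same count of heavy atoms and the same ring sizes, so the step arises without any change in those counts, although sulfur leaves, nitrogen enters and the hydrogen-bond acceptors rise from 2 to 3. Nothing available explains why this exchange gives so large a step.

The compounds shown leave open which of those atom changes carries the step. They also leave open whether it would persist with a methyl group or a chlorine on the entering group, or with a piperidine on the sulfonyl in place of the phenyl ring.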